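This account rests on a few compounds, and the source may have more. Where it says the series, first, only, none or still open, it means among the compounds named here.

The set has a shared core carrying a fluorophenyl-substituted amine and a methylpiperazinyl aniline, and differs only in the saturated ring on the core nitrogen and what that ring's nitrogen bears. Compound 1 `CN1CCN(c2ccc(Nc3ncc4nc(Nc5ccc(F)cc5)n([C@@H]5CCN(C(=O)CO)C5)c4n3)cc2)CC1` places a (hydroxymethyl)carbonyl on a five-membered ring; compound 2 `CN1CCN(c2ccc(Nc3ncc4nc(Nc5ccc(F)cc5)n([C@H]5CCCN(S(=O)(=O)C6CC6)C5)c4n3)cc2)CC1` places a cyclopropylsulfonyl on a six-membered ring; compound 3 `CN1CCN(c2ccc(Nc3ncc4nc(Nc5ccc(F)cc5)n([C@H]5CCCNC5)c4n3)cc2)CC1` carries the same six-membered ring with its nitrogen unsubstituted. In a functional assay on NCI-H1975 cells (Homo sapiens) for antiproliferative activity, read by MTT assay, with a stated time of 72 h (a higher number here means a weaker inhibitor, a lower number a stronger inhibitor), compound 2 gives 1150 nM. In this assay, among the compounds with values here, compound 1 gives "not determined" (no result reported) and compound 3 gives "not determined" (no result reported), so compound 3 has no number to stand on, and the pair it forms with compound 2 shows nothing beyond the single value of compound 2.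

Compound 4 `CN1CCN(c2ccc(Nc3ncc4nc(Nc5ccc(F)cc5)n([C@H]5CCCN(C(=O)CO)C5)c4n3)cc2)CC1` is the target of the step from compound 3: (hydroxymethyl)carbonyl in place of hydrogen on an amine nitrogen in a ring. Within the data shown here, with no measured step available for this change, the nearest anchor is compound 2, which also carries a substituted six-membered ring. Among the measured compounds shown here, the expectation is that compound 4 lands near that anchor, with no step relative to compound 2 that clearly exceeds the scatter, and a modest lean toward stronger inhibition if anything. Compound 4 is therefore estimated at 800 nM in this assay, within a range of 250 nM to 3000 nM.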

Compound 4, half-maximal inhibitory concentration: 750 nM
Compound 4: middle estimate off by 1.1-fold (0.03 log units), on the high side; the measured number falls inside the stated range.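

Within the data shown here, with a second substituent on the nitrogen of the six-membered ring now measured, this assay gives the first comparison at this position: exchanging cyclopropylsulfonyl for (hydroxymethyl)carbonyl gives a 1.5-fold lower number from compound 2 to compound 4 (0.19 log units; within the scatter), so these two groups cannot be told apart here, although one is a sulfonyl group with a ring and the other an open-chain carbonyl group. From the compounds shown here alone, the step from compound 3 to compound 4 cannot be read, so what either group contributes relative to hydrogen on this nitrogen stays unknown, and the result describes only the exchange of one substituent for the other. No measurement bears on why the two groups read alike.

The compounds shown leave open whether other groups on this ring nitrogen, such as a plain acetyl, a methanesulfonyl, a longer chain ending in an amine or a carboxylic acid, would stay at this level or move beyond the scatter. They also leave open what the ring itself contributes, since compound 1 has no number to set against compound 4, and the other stereoisomer of the six-membered ring is not among them.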